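A few compounds are considered here, and "the series" means these few. Any claim that something is new, unique, unknown or untested is made for them only; others in the source may bear on it.

Compound 3 `Cn1ccc2c(Oc3ccc(NC(=O)c4cc5cccnc5n(-c5ccccc5)c4=O)cc3)ccnc21` gives 850 nM in a functional assay on A549 cells (Homo sapiens) for antiproliferative activity, read by MTT assay, with a stated time of 72 h (on this read-out higher numbers stand for weaker inhibition and lower numbers for stronger inhibition), the second highest of the three numbers recorded: compound 1 `O=C(Nc1ccc(Oc2ccnc3[nH]ccc23)cc1)c1cc2cccnc2n(-c2ccccc2)c1=O` gives 360 nM in this assay, and compound 2 `O=C(Nc1ccc(Oc2ccnc3[nH]ccc23)cc1)c1cc2cccnc2n(-c2ccc(C(F)(F)F)cc2Cl)c1=O` gives 3230 nM in this assay. Compound 4 `Cn1ccc2c(Oc3ccc(NC(=O)c4cc5cccnc5n(-c5ccc(Cl)cc5)c4=O)cc3)ccnc21` differs from compound 3 by chloro in place of hydrogen on an aromatic carbon. Two measured steps are available. The step of a 2.4-fold higher number from compound 1 to compound 3 (0.37 log units; beyond the scatter) concerns the methyl on the other aromatic nitrogen and does not touch the phenyl in question. The step of a 9.0-fold higher number from compound 1 to compound 2 (0.95 log units; beyond the scatter) bears on it directly: it replaced that same phenyl with 2-chloro-4-(trifluoromethyl)phenyl and gave a higher number in this assay. A single chloro is a smaller change than that, so a smaller shift is expected, in the same direction toward a higher number, though a shift within the scatter cannot be ruled out. Compound 4 is therefore expected to come out at 1500 nM in this assay, a step of a 1.8-fold higher number from compound 3 to compound 4 (0.25 log units; within the scatter), within a range from 500 nM to 4500 nM.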

Compound 4, half-maximal inhibitory concentration: 630 nM
Estimate against measurement, compound 4: 2.4-fold (0.38 log units) above; the measured number falls inside the stated range.
By their numbers in this assay, from the lowest: compounds 1, 4 and 3 (each within the scatter of the next, the first and the last beyond it); then compound 2.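

The change from phenyl to 4-chlorophenyl amounts to a 1.3-fold lower number from compound 3 to compound 4 (0.13 log units; within the scatter) in this assay, so a single chloro para to a large group cannot be told apart from hydrogen on this read-out. Until now this ring was known only through the 2-chloro-4-(trifluoromethyl)phenyl change, a 9.0-fold higher number from compound 1 to compound 2 (0.95 log units; beyond the scatter), so the position now proves able to carry a substituent without a step beyond the scatter, although the two steps stand on different backgrounds, one with hydrogen and one with methyl on the other aromatic nitrogen. Nothing given here accounts for this outcome.

The compounds shown leave open which part of 2-chloro-4-(trifluoromethyl)phenyl goes with the larger step, and whether 4-chlorophenyl would behave alike with hydrogen on that nitrogen. They also leave open how a methoxy group, an amine or a carboxylic acid would fare at this place on the ring.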